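The source may hold more compounds than are shown below. What is called first, only, known or untested is meant among the compounds shown, and "the series" means these compounds.

Compounds measured so far:
compound 1 `COc1ccc(C(=O)NCc2ccc(CNS(=O)(=O)c3ccccc3)cc2)cc1`, 1000 nM
compound 2 `O=C(NCc1ccc(CNS(=O)(=O)c2ccccc2)cc1)c1cccnc1`, 10 nM
compound 3 `O=C(NCc1ccc(CNS(=O)(=O)c2ccccc2)cc1)c1ccc([N+](=O)[O-])cc1`, 100 nM

In an assay on MDA-MB-231 cells for binding affinity to C-X-C chemokine receptor type 4 (Homo sapiens), read by immunofluorescence and microscopy, with stated times of 10 min and 30 min (a higher number here means that more compound is needed for the effect, a lower number that less compound is needed), compound 3 stands second highest of the three numbers. Its nearest neighbour is compound 1, reached by a 10-fold lower number from compound 1 to compound 3 (1.00 log units; beyond the scatter); its furthest is compound 2, from which a 10-fold higher number from compound 2 to compound 3 (1.00 log units; beyond the scatter) separates it.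

Compound 4 `Cc1ccccc1C(=O)NCc1ccc(CNS(=O)(=O)c2ccccc2)cc1` has not been measured. Its change from compound 3 is 2-methylphenyl in place of 4-nitrophenyl on a carbonyl carbon. Among the measured compounds shown here, the steps that bear on it all alter the group on the carbonyl carbon: a 100-fold lower number from compound 1 to compound 2 (2.00 log units; beyond the scatter), a 10-fold lower number from compound 1 to compound 3 (1.00 log units; beyond the scatter) and a 10-fold higher number from compound 2 to compound 3 (1.00 log units; beyond the scatter). Since the 2-methylphenyl carries no acceptor, like the weaker compound 1, a higher number is expected, with a 5.0-fold higher number from compound 3 to compound 4 (0.70 log units; beyond the scatter) estimated. Compound 4 is therefore expected to give 500 nM, between 100 nM and 2500 nM.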

Compound 4, effective concentration (reported as EC, without a stated level of effect): 1 nM
For compound 4 the middle estimate is 500-fold (2.70 log units) above the measured one, outside the stated range (below it).
By their numbers in this assay, from the lowest: compound 4; then compound 2; then compound 3; then compound 1.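

In this assay, among the compounds shown here, the group on the carbonyl carbon reaches further than the earlier compounds showed, with a 1000-fold lower number from compound 1 to compound 4 (3.00 log units; beyond the scatter) and a 100-fold lower number from compound 3 to compound 4 (2.00 log units; beyond the scatter) and also a 10-fold lower number from compound 2 to compound 4 (1.00 log units; beyond the scatter). The 2-methylphenyl group has 0 hydrogen-bond acceptors, so among these four compounds hydrogen-bond acceptors in this group are not needed for the lowest number. Nothing available explains this result. The compounds shown leave open how much of the result depends on the methyl group, since plain phenyl does not appear among them. As far as these compounds go, whether a larger group such as cyclohexyl would be tolerated on this carbonyl carbon also stays open.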